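Benzofuran in place of furan on a non-toxic nucleoside

The source may hold more compounds than are shown below. What is called first, only, known or untested is meant among the compounds shown, and "the series" means these compounds.

Measured in an ADME assay on BJ cells (Homo sapiens), read by MTT assay, with a stated time of 72 h; on this read-out lower numbers stand for stronger inhibition and higher numbers for weaker inhibition:
Compound 1 `Nc1nc(N)c2c(-c3ccco3)cn([C@@H]3O[C@H](CO)[C@@H](O)[C@H]3O)c2n1`: > 100000 nM (a limit)
Compound 2 `COc1nc(N)nc2c1c(-c1ccco1)cn2[C@@H]1O[C@H](CO)[C@@H](O)[C@H]1O`: > 100000 nM (a limit)

Compound 2 gives > 100000 nM, which is a limit of the assay and not a number. The same holds across the small set, as the limit of > 100000 nM in this assay, at which 2 of the 2 values shown sit, shows. So the starting point is known only as a bound, with no exact value to build on.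

Compound 3 `COc1nc(N)nc2c1c(-c1cc3ccccc3o1)cn2[C@@H]1O[C@H](CO)[C@@H](O)[C@H]1O` keeps the rest of compound 2 and carries 1-benzofuran-2-yl in place of furan-2-yl on an aromatic carbon. Among the measured compounds shown here, the one measured step is a step that the two limits leave unreadable from compound 1 to compound 2. It concerns a different change, methoxy in place of amino on an aromatic carbon, and it gives no size to carry over. For the measured compounds named here, no measured step touches the furan-2-yl group, so any forecast in this assay is cautious. Compound 3 may well stay at the limit too. The expected change is an at least 1.4-fold lower number from compound 2 to compound 3 (0.15 log units; that floor lies within the scatter), a modest move toward stronger inhibition if a number appears at all. For compound 3 the estimated value is 70000 nM, with an expected range of 15000 nM to 100000 nM.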

Compound 3, half-maximal inhibitory concentration: 25600 nM
Beside the measured number, compound 3's estimate is 2.7-fold (0.44 log units) above it; the measured number falls inside the stated range.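

Swapping furan-2-yl for 1-benzofuran-2-yl on this aromatic carbon gives, in this assay, an at least 3.9-fold lower number from compound 2 to compound 3 (0.59 log units; beyond the scatter), so the group at this position can move the read-out, which neither earlier compound could show. Among the compounds shown here, compound 3 is also the first compound here with an exact number rather than a limit, which gives any further change a value to be compared with. Because compound 2 is known only as a limit, the size of this step is a floor and the real difference could be larger: the limit of > 100000 nM in this assay, at which 2 of the 3 values shown sit.

The compounds shown leave open whether the added six-membered aromatic ring of carbon only is what counts, or whether a simple phenyl group, or a 1-benzofuran-2-yl group carrying a chlorine atom or an amine, would give a similar number. On these data alone, it is also open whether the same swap on compound 1, which has amino in place of methoxy, would bring a number out of the limit, and the step between compound 1 and compound 2 cannot be read.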